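Methyl added to compound 2: expected growth inhibition

A few compounds are considered here, and "the series" means these few. Any claim that something is new, unique, unknown or untested is made for them only; others in the source may bear on it.

Among the compounds with values here, in a functional assay on A549 cells (Homo sapiens) for inhibition (a lower number here means a stronger inhibitor of growth, a higher number a weaker inhibitor of growth), compound 1 `CC(C)(C)c1ccc(S(=O)(=O)Nc2ccccc2)cc1` gives 16000 nM as its value and compound 2 `CC(C)(C)c1ccc(S(=O)(=O)Nc2ccccc2O)cc1` gives 13000 nM as its value, so compound 2 stands level with the only other measured compound, within the scatter.

Compound 3 `Cc1ccc(NS(=O)(=O)c2ccc(C(C)(C)C)cc2)c(O)c1` carries one further change from compound 2: methyl in place of hydrogen on an aromatic carbon with the new group meta to the hydroxy group and para to a large group.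

Within the data shown here, no measured step covers a methyl group. Among the measured compounds shown here, the one step available is a 1.2-fold lower number from compound 1 to compound 2 (0.09 log units; within the scatter) and it concerns a hydroxy group, so it is only a loose guide. Its small size gives no ground to expect a shift beyond the scatter in this assay for the new change, in either direction.

The expected step is a 1.2-fold lower number from compound 2 to compound 3 (0.07 log units; within the scatter) and it is estimated to stay within the scatter. For compound 3 the estimated value is 11000 nM with an expected range from 5500 nM to 22000 nM in this read-out.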

Compound 3, concentration for 50% growth inhibition: 8000 nM
Beside the measured number, compound 3's estimate is 1.4-fold (0.14 log units) above it; low and high end bracket the measured number.
By their numbers in this assay, from the lowest: compounds 3, 2 and 1 (each within the scatter of the next).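

In this assay, methyl in place of hydrogen on an aromatic carbon, meta to a hydroxy group and para to a large group, gives a 1.6-fold lower number from compound 2 to compound 3 (0.21 log units; within the scatter). Within the data shown here, this is the first measured step for a methyl group, and it shows that this carbon of the six-membered aromatic ring can carry methyl with the growth-inhibition number still within the scatter of that of compound 2, so the step gives no firm sign of a gain or a loss. Nothing measured alongside these numbers bears on the reason for this outcome.

With the two steps shown both within the scatter, it remains open whether any change on this ring can move the number beyond the scatter, and whether an ethyl group, a longer chain, an amine or a carboxylic acid at the same carbon would do so. Also open is whether methyl at this carbon would give a similar step in a compound without the hydroxy group, since the only methyl step shown has that group present.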